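This account rests on a few compounds, and the source may have more. Where it says the series, first, only, none or still open, it means among the compounds named here.

Measured so far:
- compound 1 `C=CCc1ccc(OCc2cn(-c3ccccc3CO)nn2)c(O)c1` — 12.9%
- compound 2 `C=CCc1ccc(OCc2cn(-c3cc(OC)c(OC)c(OC)c3)nn2)c(O)c1` — 44.1%

Both numbers come from a functional assay on SK-N-SH cells (Homo sapiens) for inhibition, read by MTT assay, with a stated time of 72 h, tested at 30 uM; a lower number here means less inhibition of growth, a higher number more inhibition of growth at the concentration tested. Compound 1 stands lowest of the two: compound 2 gives 44.1% and compound 1 gives 12.9%, and the gap between the two lies beyond the usual scatter. Going by the values given here, the two compounds share the same core and differ only in the aryl group on the aromatic nitrogen, so the data say nothing yet about a single change repeated across pairs; no step between two measured compounds can be stated.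

Compound 3 `C=CCc1ccc(OCc2cn(-c3ccc(C#N)cc3)nn2)c(O)c1` is not yet measured. It differs from compound 1 in one place: 4-cyanophenyl in place of 2-(hydroxymethyl)phenyl on an aromatic nitrogen. With only compound 1 and compound 2 in hand, the step from compound 1 to compound 3 cannot be anchored to a measured step; the expectation rests on compound 1 alone, with compound 2 showing that another aryl group on the same nitrogen gives a higher number. The step is expected to be upward and modest, a number 12.1 percentage points higher from compound 1 to compound 3 (beyond the scatter), not far beyond the scatter. For compound 3 the estimate in this assay is 25%, within a range of 5% to 50%.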

Compound 3, percent growth inhibition at one concentration: 37.5%
Compound 3: the middle estimate sits 12.5 percentage points below what was measured; low and high end bracket the measured number.
By their numbers in this assay, from the lowest: compound 1; then compounds 3 and 2 (each within the scatter of the next).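

In this assay the change from 2-(hydroxymethyl)phenyl to 4-cyanophenyl on the aromatic nitrogen gives a number 24.6 percentage points higher from compound 1 to compound 3 (beyond the scatter) with the shared core left unchanged, so this position gives a first readable step from one aryl group to another. Compound 3 at 37.5% and compound 2 at 44.1% lie within the scatter of each other, so these two aryl groups cannot be told apart here, while compound 1 lies beyond the scatter from both. Nothing on hand bears on the reason for the step at this position.

Going by these compounds alone, the single step does not separate the arrival of the nitrile from the departure of the hydroxymethyl group, and the two groups also carry their substituents at different places on the phenyl ring. Also open, as far as these compounds go, is how a plain phenyl, a 4-aminophenyl or a 4-carboxyphenyl on the same nitrogen would read, and whether any of these would stand apart from compound 2 and compound 3 by more than the scatter.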